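Removing a Carboxy Group From a Sulfone Amide Series

The compounds below may be only part of what the source reports. "The series", "measured", "known", "first", "only" and "open" are said of these compounds alone.

Of the compounds shown here, three of one family have been tested in a toxicity assay on J774.1 cells (Mus musculus) for cytotoxicity, read by MTT assay, with a stated time of 48 h; a lower number here means that less compound is tolerated, a higher number that more compound is tolerated. Compound 1 `O=C(NCc1ccccc1C(=O)N[C@H](/C=C(\F)S(=O)(=O)Oc1ccccc1)CCc1ccccc1)c1ccc2c(c1)OCCO2` gives > 100000 nM, which is a limit of the assay rather than a number. Compound 2 `O=C(NCc1ccccc1C(=O)N[C@H](/C=C(\F)S(=O)(=O)Oc1ccccc1)CCc1ccccc1)c1ccncc1` likewise gives > 100000 nM, again a limit. The step that the two limits leave unreadable from compound 1 to compound 2 therefore cannot be sized. Compound 3 `O=C(O)c1cccc(C(=O)NCc2ccccc2C(=O)N[C@H](/C=C/S(=O)(=O)c2ccccc2)CCc2ccccc2)c1` also gives > 100000 nM, a limit. It stands where the other two stand, as the limit of > 100000 nM in this assay, at which 3 of the 3 values shown sit, shows, so no ordering among the three can be drawn.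

Compound 4 `O=C(NCc1ccccc1C(=O)N[C@H](/C=C/S(=O)(=O)c1ccccc1)CCc1ccccc1)c1ccccc1` has not been measured. It differs from compound 3 in one place: hydrogen in place of carboxy on an aromatic carbon. Going by the values given here, no measured step carries this change, and the one step that is measured is itself unreadable, so nothing here points to either direction. Since every measured member of the family sits at the limit, compound 4 is expected to do the same, with the step that the limit leaves unreadable from compound 3 to compound 4 expected to stay within the scatter. Compound 4 is estimated at 150000 nM, between 50000 nM and 500000 nM, and most likely reported only as a limit.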

Compound 4, half-maximal cytotoxic concentration: > 100000 nM
Compound 4 ended at the assay's limit; the forecaster's own chance of this, stated with the estimate: 85%; the middle value is on the limit's open side.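

The step from compound 3 to compound 4, hydrogen in place of carboxy, cannot be read, because both compounds give only a limit and not a number: the limit of > 100000 nM in this assay, at which 4 of the 4 values shown sit.

The compounds shown leave open how much of any of them is tolerated in this assay, and so whether removing the carboxy group changes that at all.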